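The compounds below may be only part of what the source reports. "The series", "measured", "known", "first", "only" and "open" are said of these compounds alone.

Working notes on the series

Three members of the series have been run in a functional assay on HCT-15 cells (Homo sapiens) for cytotoxicity, read by CCK-8 assay and cell counting, with a stated time of 2 days; on this read-out higher numbers stand for weaker inhibition and lower numbers for stronger inhibition. Compound 1 `Oc1cccc(-c2cc(-c3cccc(Cl)c3)nc(-c3cccs3)c2)c1` gives 2610 nM. Compound 2 `Oc1cccc(-c2cc(-c3ccsc3)nc(-c3ccccc3Cl)c2)c1` gives 2500 nM, and compound 3 `Oc1cccc(-c2cc(-c3ccccc3)nc(-c3ccccc3Cl)c2)c1` gives 2930 nM. The three numbers sit close together: the nearest to compound 3 is compound 1, the furthest is compound 2, and both gaps lie within the scatter of repeat measurements, so no order among the three can be read from them.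

Compound 4 `Oc1cccc(-c2cc(-c3cccs3)nc(-c3ccccc3Cl)c2)c1` differs from compound 3 in one place: thiophen-2-yl in place of phenyl on an aromatic carbon

Among the measured compounds shown here, one measured step bears on this change. The swap of phenyl for thiophen-3-yl gave a 1.2-fold higher number from compound 2 to compound 3 (0.07 log units; within the scatter). For the measured compounds named here, compound 1 also carries a thiophen-2-yl group, though paired with a 3-chlorophenyl group where compound 4 has a 2-chlorophenyl group, so no single-place step links it to compound 3 or compound 4; its value and that of compound 3 lie within the scatter of each other.

Taken together, a move between phenyl and a thiophene ring at this place has so far produced nothing beyond the scatter, so the step from compound 3 to compound 4 in this assay is expected to be a 1.1-fold lower number from compound 3 to compound 4 (0.05 log units; within the scatter). On that basis compound 4 is estimated at 2600 nM, with a range of 1300 nM to 5200 nM.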

Compound 4, half-maximal inhibitory concentration: 2790 nM
Beside the measured number, compound 4's estimate is 1.1-fold (0.03 log units) below it, and the stated range covers the measured number.
By their numbers in this assay, from the lowest: compounds 2, 1, 4 and 3 (each within the scatter of the next).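

At this place, next to the ring nitrogen, thiophen-2-yl in place of phenyl gives a 1.1-fold lower number from compound 3 to compound 4 (0.02 log units; within the scatter) in this assay, and thiophen-2-yl in place of thiophen-3-yl gives a 1.1-fold higher number from compound 2 to compound 4 (0.05 log units; within the scatter), so phenyl and both thiophene attachments now stand within the scatter of each other with the 2-chlorophenyl group held constant. Compound 4 also gives the first single-place link to compound 1: with thiophen-2-yl held constant, 2-chlorophenyl in place of 3-chlorophenyl gives a 1.1-fold higher number from compound 1 to compound 4 (0.03 log units; within the scatter), so this change in the chlorine's place on the phenyl ring also stays within the scatter. The data offer no measurement that would account for this flat response.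

On these data alone, all three groups compared at this place are uncharged aromatic rings, so it remains open whether an amine, a carboxylic acid or a longer alkyl chain there would move the number beyond the scatter. The 3-hydroxyphenyl group is common to all four compounds, which leaves its part in the cytotoxicity unresolved, as would be tested by a methoxy group or a bare phenyl ring in its place.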